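Moving the Nitro Group on a Rhodanine-Triazole Series

The source may report more compounds than this note shows. Statements on the series, on what has been measured and on what is new or still open speak of the compounds shown alone.

Measured compounds:
compound 1 `O=C1NC(=O)/C(=C/c2ccc(OCCSc3nnc(-c4ccccc4)[nH]3)cc2)S1`: 10.4%
compound 2 `O=C1NC(=O)/C(=C/c2ccc(OCCSc3nnc(-c4ccc([N+](=O)[O-])cc4)[nH]3)cc2)S1`: 11.9%

In a functional assay on the whole organism (plasma, strain Wistar) with Rattus norvegicus as the target, with a stated time of 15 days, at a dose of 3 mg/kg by the oral route (on this read-out higher numbers stand for a stronger effect at the one dose given and lower numbers for a weaker effect), compound 2 and compound 1 lie within the usual scatter of each other. Going by the values given here, the one step measured, a number 1.5 percentage points higher from compound 1 to compound 2 (within the scatter), was within the scatter. Compound 3 `O=C1NC(=O)/C(=C/c2ccc(OCCSc3nnc(-c4ccccc4[N+](=O)[O-])[nH]3)cc2)S1` differs from compound 2 in one place: 2-nitrophenyl in place of 4-nitrophenyl on an aromatic carbon. Among the compounds with values here, no measured step shifts a group already present, so only the small nitro step offers any guidance. Compound 3 is therefore expected to show no step beyond the scatter, a number 0.9 percentage points lower from compound 2 to compound 3 (within the scatter), and compound 3 is estimated at 11%, between 3% and 20%.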

Compound 3, a percentage reported as activity, at one dose (the size of the read-out at that dose, not a potency): 14.6%
The estimate for compound 3 lay 3.6 percentage points below the measured number, and the stated range covers the measured number.
By their numbers in this assay, from the lowest: compounds 1, 2 and 3 (each within the scatter of the next).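

In this assay, 2-nitrophenyl in place of 4-nitrophenyl on the aromatic carbon between two ring nitrogen atoms gives a number 2.7 percentage points higher from compound 2 to compound 3 (within the scatter) and so shows that shifting the nitro group here gives no step beyond the scatter. Nitro in place of hydrogen, in this second arrangement, gives a number 4.2 percentage points higher from compound 1 to compound 3 (within the scatter) and so likewise does not set 2-nitrophenyl apart from the phenyl of compound 1. Nothing available speaks to what lies behind these numbers.

As far as these compounds go, whether an amine or a carboxylic acid on that phenyl ring would give a step beyond the scatter remains open.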